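Imine aryl swap on the sulfonamide-bearing core

The source may report more compounds than this note shows. Statements on the series, on what has been measured and on what is new or still open speak of the compounds shown alone.

The three measured compounds share one core. Compound 1 `N#CC1=C(NC(=O)C2CC2)N(c2ccc(S(N)(=O)=O)cc2)C2=C(C(=O)CCC2)C1c1ccc(Cl)cc1Cl` carries a cyclopropyl amide, compound 2 `N#CC1=C(NC(=O)/C=C/c2ccccc2)N(c2ccc(S(N)(=O)=O)cc2)C2=C(C(=O)CCC2)C1c1ccc(Cl)cc1Cl` a cinnamoyl amide, and compound 3 `CN(C)c1ccc(/C=N/C2=C(C#N)C(c3ccc(Cl)cc3Cl)C3=C(CCCC3=O)N2c2ccc(S(N)(=O)=O)cc2)cc1` an imine to 4-(dimethylamino)phenyl. In a functional assay on Ehrlich cells (Mus musculus) for cytotoxicity, read by trypan blue exclusion, with a stated time of 2 h (on this read-out lower numbers stand for stronger inhibition and higher numbers for weaker inhibition), compound 1 gives 75 ug/mL. Compound 2 reaches only the limit of this assay, > 100 ug/mL. Compound 3 likewise stands at the limit, > 100 ug/mL, so its place on the scale is known only as a floor. The measured steps read an at least 1.3-fold higher number from compound 1 to compound 2 (0.12 log units; that floor lies within the scatter) and an at least 1.3-fold higher number from compound 1 to compound 3 (0.12 log units; that floor lies within the scatter); the pair of limits leaves a step that the two limits leave unreadable from compound 2 to compound 3, since the limit of > 100 ug/mL in this assay, at which 2 of the 3 values shown sit, covers both ends of it.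

Compound 4 `N#CC1=C(/N=C/c2ccc([N+](=O)[O-])cc2[N+](=O)[O-])N(c2ccc(S(N)(=O)=O)cc2)C2=C(C(=O)CCC2)C1c1ccc(Cl)cc1Cl` differs from compound 3 in one place: 2,4-dinitrophenyl in place of 4-(dimethylamino)phenyl on a carbon with a double bond to nitrogen. For the measured compounds named here, no measured step touches a substituent on this aryl ring; the only step that reaches the imine at all is the one from the amide, and it carries no readable size. The expectation for compound 4 therefore starts from the limit and stays wide. Compound 4 is expected at 100 ug/mL, with a range from 40 ug/mL to 250 ug/mL. The expected step is a number no higher from compound 3 to compound 4 (the limit leaves the size open), with a fair chance that compound 4 again returns only the limit.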

Compound 4, half-maximal inhibitory concentration: > 100 ug/mL
Compound 4: a limit, no number; the forecaster's own chance of this, stated with the estimate: 55%; the middle value sits exactly at the limit.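

Compound 4 returns only a limit, > 100 ug/mL, so no step from compound 3 to compound 4 can be read: the limit of > 100 ug/mL in this assay, at which 3 of the 4 values shown sit.

The compounds shown leave open whether 2,4-dinitrophenyl and 4-(dimethylamino)phenyl differ in cytotoxicity, and where compound 2, compound 3 and compound 4 actually lie on the scale.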